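The source may report more compounds than this note shows. Statements on the series, on what has been measured and on what is new or still open speak of the compounds shown alone.

Compound 1 `O=C(Nc1ccc2[nH]ncc2n1)[C@H]1CCCN1C(=O)C1(c2cccc(Cl)c2)CCCC1`: 0.159 nM
Compound 2 `O=C(Nc1ccc2[nH]ncc2c1)[C@H]1CCCN1C(=O)C1(c2cccc(Cl)c2)CCCC1`: 1 nM

Both compounds were tested in an assay on isolated protein for inhibition of histone acetyltransferase p300 (Homo sapiens), with a stated time of 60 min; a lower number here means a stronger inhibitor, a higher number a weaker inhibitor. Of the two measured numbers, compound 2 carries the higher one, and the single step shown, a 6.3-fold higher number from compound 1 to compound 2 (0.80 log units; beyond the scatter), comes from a change within the same aromatic group attached to the amide nitrogen. Compound 3 `O=C(Nc1ccc(O)cc1)[C@H]1CCCN1C(=O)C1(c2cccc(Cl)c2)CCCC1` has not yet been measured. It differs from compound 2 by 4-hydroxyphenyl in place of 1H-indazol-5-yl on an amide-type nitrogen. Within the data shown here, no measured step exchanges a two-ring group for a single ring in this manner, so the one step available serves only as a rough guide: it shows that an alteration at this end of the molecule can shift the number beyond the scatter. For compound 3 the number in this assay is expected to rise, by about a 20-fold higher number from compound 2 to compound 3 (1.30 log units; beyond the scatter). Compound 3 is therefore estimated at 20 nM, with a range from 3 nM to 150 nM.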

Compound 3, half-maximal inhibitory concentration: 0.631 nM
The estimate for compound 3 lay 32-fold (1.50 log units) above the measured number; the whole stated range lies above it.
By their numbers in this assay, from the lowest: compound 1; then compounds 3 and 2 (each within the scatter of the next).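

In this assay the step from the two-ring 1H-indazol-5-yl to the single-ring 4-hydroxyphenyl on the amide-type nitrogen is a 1.6-fold lower number from compound 2 to compound 3 (0.20 log units; within the scatter), so at this position the five-membered aromatic ring of compound 2 is not required to keep a number of this size. The group of compound 1 still stands apart, with a 4.0-fold higher number from compound 1 to compound 3 (0.60 log units; beyond the scatter), and compound 1 remains the strongest of the three inhibitors. Nothing measured here accounts for the close match between the 1H-indazol-5-yl and 4-hydroxyphenyl groups.

As far as these compounds go, it remains open whether the hydroxy group of compound 3 matters at all, which a plain phenyl, 4-methoxyphenyl or 4-aminophenyl group on this nitrogen could test. Also open, from the compounds shown here alone, is whether a single ring containing a ring nitrogen, such as a hydroxypyridinyl group, would reach the number of compound 1.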